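Hydrazone aryl exchange: from compound 2 to compound 3

The compounds below may be only part of what the source reports. "The series", "measured", "known", "first", "only" and "open" are said of these compounds alone.

In a functional assay on the whole organism (strain Wistar) for inhibition, with Rattus norvegicus as the target, read by paw edema, with a stated time of 1 h, at a dose of 10 mg/kg by the intraperitoneal route (on this read-out lower numbers stand for less inhibition and higher numbers for more inhibition at the one dose given (going by the name of the read-out)), compound 2 `O=C(N/N=C/c1ccc(O)cc1)c1cccnc1Nc1cccc(C(F)(F)F)c1` gives 70.5%. Compound 1 `O=C(N/N=C/c1ccc(Cl)cc1)c1cccnc1Nc1cccc(C(F)(F)F)c1` gives 67.2% in this assay, and the step of a number 3.3 percentage points higher from compound 1 to compound 2 (within the scatter) means compound 2 stands level with compound 1 within the scatter. Compound 3 `O=C(N/N=C/c1ccncc1)c1cccnc1Nc1cccc(C(F)(F)F)c1` differs from compound 2 by pyridin-4-yl in place of 4-hydroxyphenyl on a carbon with a double bond to nitrogen. Going by the values given here, the only measured step at this part of the structure, from chloro to hydroxy, stayed within the scatter, so no step beyond the scatter is expected for compound 3 in this assay, the expected step being a number 2.5 percentage points lower from compound 2 to compound 3 (within the scatter). Compound 3 is therefore estimated at 68%, with a range from 55% to 80%.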

Compound 3, a percentage reported as inhibition, in the whole organism at one dose (the size of the read-out at that dose, not a potency): 70.2%
Compound 3: the middle estimate sits 2.2 percentage points below what was measured, within the range that was stated.
By their numbers in this assay, from the lowest: compounds 1, 3 and 2 (each within the scatter of the next).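

In this assay, pyridin-4-yl in place of 4-hydroxyphenyl on a carbon with a double bond to nitrogen gives a number 0.3 percentage points lower from compound 2 to compound 3 (within the scatter), and pyridin-4-yl in place of 4-chlorophenyl gives a number 3 percentage points higher from compound 1 to compound 3 (within the scatter). At this position, then, exchanging the whole aromatic ring for one with a hetero atom, and not only the group on that ring, produces no step beyond the scatter. Nothing available explains this level reading.

Going by these compounds, whether any group here moves the read-out beyond the scatter remains open. A phenyl ring carrying a carboxylic acid or an amine, or a saturated ring such as cyclohexyl, lies outside the compounds shown.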